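Ester for ether on the side-chain oxygen of a quinone

The source may hold more compounds than are shown below. What is called first, only, known or untested is meant among the compounds shown, and "the series" means these compounds.

The two measured compounds share a core and differ only in the group on an oxygen on a saturated carbon. Compound 1 `CC[C@@](C)(O)CC(=O)O[C@H](CC=C(C)C)C1=CC(=O)c2c(O)ccc(O)c2C1=O` carries a (2-hydroxy-2-methylbutyl)carbonyl there; in a functional assay on DU-145 cells (Homo sapiens) for cytotoxicity, read by MTT assay (on this read-out lower numbers stand for stronger inhibition and higher numbers for weaker inhibition), compound 1 gives 12700 nM. Compound 2 `CC(C)=CC[C@@H](OCCO)C1=CC(=O)c2c(O)ccc(O)c2C1=O` carries a 2-hydroxyethyl instead; in this assay compound 2 gives 9900 nM. The step of a 1.3-fold lower number from compound 1 to compound 2 (0.11 log units; within the scatter) sits within the scatter, so compound 2 stands alongside compound 1 with nothing to separate them.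

Compound 3 `CC(C)=CC[C@@H](OC(=O)C1CCCOC1)C1=CC(=O)c2c(O)ccc(O)c2C1=O` is not yet measured. It differs from compound 2 in the same place: (oxan-3-yl)carbonyl in place of 2-hydroxyethyl on an oxygen on a saturated carbon. This reverses the kind of change seen from compound 1 to compound 2, moving from a 2-hydroxyethyl back to a carbonyl-bearing group on that oxygen. Within the data shown here, the only step that bears on it, a 1.3-fold lower number from compound 1 to compound 2 (0.11 log units; within the scatter), showed no movement beyond the scatter when an acyl group gave way to a 2-hydroxyethyl. An acyl group returning, now as (oxan-3-yl)carbonyl, is therefore expected to change this assay by no more than the scatter, in either direction. Compound 3 is thus estimated at 11500 nM, with a range from 4500 nM to 30000 nM, which is the step of a 1.2-fold higher number from compound 2 to compound 3 (0.07 log units; within the scatter) expected from compound 2.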

Compound 3, half-maximal inhibitory concentration: 29700 nM
Estimate against measurement, compound 3: 2.6-fold (0.41 log units) below; the range from low to high includes it.
By their numbers in this assay, from the lowest: compounds 2 and 1 (each within the scatter of the next); then compound 3.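

Among these compounds, this position is not indifferent to what sits on the oxygen: in this assay the change to (oxan-3-yl)carbonyl gives a 3.0-fold higher number from compound 2 to compound 3 (0.48 log units; beyond the scatter), a movement the first pair of compounds did not show. The acyl groups also differ from each other, since replacing 2-hydroxy-2-methylbutyl with oxan-3-yl on the carbonyl carbon gives a 2.3-fold higher number from compound 1 to compound 3 (0.37 log units; beyond the scatter), so an ester on this oxygen carries no single effect relative to the 2-hydroxyethyl ether: the ester of compound 1 lies within the scatter of compound 2, while the ester of compound 3 lies beyond it, with weaker inhibition. No supporting measurement is available to explain this difference between the two esters.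

The oxan-3-yl group brings a six-membered ring and removes the hydroxy group of the other two side chains in the same step, so the compounds shown cannot separate the effect of the ring from the loss of that hydroxy group. They also leave open how the position would respond to a carbonyl bearing a plain pentyl chain, or to a ring carrying an amine, such as piperidin-3-yl, in place of oxan-3-yl.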